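Swapping a side chain on the shared core

This account rests on a few compounds, and the source may have more. Where it says the series, first, only, none or still open, it means among the compounds named here.

Measured in a physicochemical assay for solubility, read by HPLC, with a stated time of 24 h, at pH 7.4, tested at 250 uM; on this read-out higher numbers stand for higher solubility and lower numbers for lower solubility:
- Compound 1 `NC(=O)C1CCN(c2nc(-c3ccccn3)nc3c2CN(Cc2ccccc2)CC3)CC1`: 250000 nM
- Compound 2 `CN1CCN(CCCNc2nc(-c3ccccn3)nc3c2CN(Cc2ccccc2)CC3)CC1`: 180000 nM

Among the compounds with values here, compound 2 and compound 1 are the only two measured compounds, and their numbers lie within the scatter of each other. Compound 3 `CN(C)CCN1CCN(c2nc(-c3ccccn3)nc3c2CN(Cc2ccccc2)CC3)CC1` keeps the shared core and differs from compound 2 as follows: 4-(2-(dimethylamino)ethyl)piperazin-1-yl in place of (3-(4-methylpiperazin-1-yl)propyl)amino on an aromatic carbon. Here 4-(2-(dimethylamino)ethyl)piperazin-1-yl stands in place of (3-(4-methylpiperazin-1-yl)propyl)amino on an aromatic carbon, the two groups having the same atoms, joined differently. Within the data shown here, one measured step bears on this, an exchange on an aromatic carbon too: a 1.4-fold lower number from compound 1 to compound 2 (0.14 log units; within the scatter). On that single step, no change beyond the scatter is expected in this assay. The expected step is a 1.1-fold higher number from compound 2 to compound 3 (0.05 log units; within the scatter). For compound 3 the estimated value is 200000 nM, with an expected range of 110000 nM to 250000 nM.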

Compound 3, solubility: 218000 nM
Estimate against measurement, compound 3: 1.1-fold (0.04 log units) below; measured number inside the range.
By their numbers in this assay, from the lowest: compounds 2, 3 and 1 (each within the scatter of the next).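

In this assay, moving from (3-(4-methylpiperazin-1-yl)propyl)amino to 4-(2-(dimethylamino)ethyl)piperazin-1-yl on this aromatic carbon keeps the same atoms but drops the hydrogen-bond donor of the group, and the result is a 1.2-fold higher number from compound 2 to compound 3 (0.08 log units; within the scatter). Set against 4-carbamoylpiperidin-1-yl, the same entering group gives a 1.1-fold lower number from compound 1 to compound 3 (0.06 log units; within the scatter), so the three groups at this position cannot be told apart in this read-out. No evidence is available that bears on these steps.

Going by these compounds, whether a carboxylic acid or a morpholine at this position would move the number beyond the scatter remains open. On these data alone, compound 1 gives 250000 nM in this assay, the same as the concentration tested, so it is also open whether this read-out could separate these compounds at all.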